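The compounds below may be only part of what the source reports. "The series", "measured", "known", "first", "only" and "open" are said of these compounds alone.

In a functional assay on Malme-3M cells (Homo sapiens) for cytotoxicity, read by MTT assay, with a stated time of 6 days (on this read-out lower numbers stand for an effect already at smaller amounts and higher numbers for an effect only at larger amounts of compound), the measured compounds are:

Compound 1 `COC(=O)c1c(-c2ccc(OC)cc2)oc2ccccc2c1=O` gives > 25 ug/mL, which is a limit of the assay.
Compound 2 `COC(=O)c1c(-c2ccc([N+](=O)[O-])cc2)oc2ccccc2c1=O` gives > 25 ug/mL, also a limit.
Compound 3 `COC(=O)c1c(-c2ccc(O)cc2)oc2ccccc2c1=O` gives > 25 ug/mL, again a limit.

All three sit at the limit of > 25 ug/mL in this assay, at which 3 of the 3 values shown sit, so none of them has a measured number. The change hydrogen in place of methyl on an oxygen on an aromatic ring gives a step that the two limits leave unreadable from compound 1 to compound 3. The cores of compound 1 and compound 2 differ by nitro in place of methoxy on an aromatic carbon, a step that the two limits leave unreadable from compound 1 to compound 2. Compound 4 `O=C(O)c1c(-c2ccc([N+](=O)[O-])cc2)oc2ccccc2c1=O` is not yet measured; it arises from compound 2 by hydrogen in place of methyl on an oxygen next to a carbonyl group. The place is not the same: in compound 3 the oxygen sits on an aromatic ring whose other neighbours are aromatic carbon, whereas in compound 4 it sits next to a carbonyl group whose other neighbours are carbonyl carbon, so this is the same kind of change, not the same change. Because every measured value stops at the limit of > 25 ug/mL in this assay, at which 3 of the 3 values shown sit, the step is expected to be a step that the limit leaves unreadable from compound 2 to compound 4. Compound 4 is therefore estimated at 35 ug/mL, most likely again only a limit, with an expected range from 15 ug/mL to 120 ug/mL.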

Compound 4, concentration for half-maximal effect: > 25 ug/mL
Compound 4 ended at the assay's limit; the forecaster's own chance of this, stated with the estimate: 85%; the middle value lies beyond the limit too.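

Among these compounds, compound 2 and compound 4 both end at a limit of the assay, so no step between them can be read: the limit of > 25 ug/mL in this assay, at which 4 of the 4 values shown sit.
The compounds shown leave open whether any change to the shared core gives a measured number in this assay at all.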